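Lipophilicity of the shared core: aryl swap from compound 1

The compounds below may be only part of what the source reports. "The series", "measured", "known", "first", "only" and "open" are said of these compounds alone.

Compound 1 `CC[C@@H](Nc1c(C#N)c(-c2ccc(-c3cccnc3C)cc2)nc2cnccc12)C(N)=O` gives 1.9 in a physicochemical assay for lipophilicity, read by HPLC, at pH 7.5; on this read-out higher numbers stand for higher lipophilicity and lower numbers for lower lipophilicity. Compound 2 `CCOc1ccccc1-c1ccc(-c2nc3cnccc3c(C[C@H](C)C(=O)O)c2C#N)cc1` gives 2.2 in this assay; the two values lie within the scatter of each other, so compound 1 stands at the lower of the two numbers without any real separation from compound 2. Compound 3 `CC[C@@H](Nc1c(C#N)c(-c2ccc(-c3ccccc3NC)cc2)nc2cnccc12)C(N)=O` is not yet measured. Compared with compound 1, the change is 2-(methylamino)phenyl in place of 2-methylpyridin-3-yl on an aromatic carbon. Within the data shown here, no measured pair shows this kind of change, so the expected step rests on the structural change alone. The step from compound 1 to compound 3 is expected to be a moderate rise, a number 0.70 log units higher from compound 1 to compound 3 (beyond the scatter), clearly beyond the scatter. For compound 3 the estimate in this assay is 2.6, with a range from 2.1 to 3.1.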

Compound 3, distribution coefficient: 2.5
Compound 3: the middle estimate sits 0.10 log units above what was measured; the range from low to high includes it.
By their numbers in this assay, from the lowest: compounds 1, 2 and 3 (each within the scatter of the next, the first and the last beyond it).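

Compound 1 and compound 2 differ in more than one place, so the pair showed nothing about this position alone; in this assay, putting 2-(methylamino)phenyl in place of 2-methylpyridin-3-yl on an aromatic carbon, para to a large group, now gives a single-place step, a number 0.60 log units higher from compound 1 to compound 3 (beyond the scatter). This one change replaces a six-membered aromatic ring with 1 hetero atom by a ring of carbon only and also brings in a hydrogen-bond donor, and a single pair cannot separate these two differences. No measurement on hand accounts for the size of this step.

A 2-methylphenyl group at the same position would set the carbon-only ring apart from the methylamino group. The compounds shown also leave open whether the step holds with the carboxylic acid side chain of compound 2 on the shared core.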